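Pyridin-2-yl to propyl: working notes on compound 3

The compounds below may be only part of what the source reports. "The series", "measured", "known", "first", "only" and "open" are said of these compounds alone.

In a functional assay on a cell-free system (plasma, Homo sapiens), with a stated time of 3 min (on this read-out lower numbers stand for stronger inhibition and higher numbers for weaker inhibition), compound 1 (`O=C(NCc1cc(Cl)ccc1-n1cnnn1)[C@@H]1[C@@H]2C[C@@H]2CN1C(=O)[C@H](O)Cc1ccccn1`) gives 1700 nM and compound 2 (`O=C([C@H](O)c1ccccc1)N1CC[C@@H]2C[C@@]21C(=O)NCc1cc(Cl)ccc1-n1cnnn1`) gives 1100 nM as its value. These two numbers lie within the scatter of each other, so compound 1 stands level with compound 2 and the pair sets no order.

Compound 3 (`CCCC[C@@H](O)C(=O)N1C[C@H]2C[C@H]2[C@H]1C(=O)NCc1cc(Cl)ccc1-n1cnnn1`) keeps the core of compound 1 and carries propyl in place of pyridin-2-yl on a saturated chain carbon, two bonds along the chain from a carbonyl carbon and an oxygen on a saturated carbon.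

Going by the values given here, no measured pair isolates a change of this kind, so the expectation rests on the structural change alone and stays loose. In this assay the expected change is small and towards stronger inhibition, an estimated 1.9-fold lower number from compound 1 to compound 3 (0.28 log units; within the scatter) that need not clear the scatter. The value expected for compound 3 is 900 nM within an estimated range of 200 nM to 4000 nM for now.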

Compound 3, half-maximal inhibitory concentration: 750 nM
Compound 3: middle estimate off by 1.2-fold (0.08 log units), on the high side, within the range that was stated.
By their numbers in this assay, from the lowest: compounds 3, 2 and 1 (each within the scatter of the next, the first and the last beyond it).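

The step in this assay is a 2.3-fold lower number from compound 1 to compound 3 (0.36 log units; beyond the scatter) and it shows that, on this saturated chain carbon, two bonds along the chain from a carbonyl carbon and an oxygen on a saturated carbon, the pyridin-2-yl group is not required for inhibition on the core of compound 1: propyl, with no ring and no hydrogen-bond acceptor, gives a modest gain rather than a loss. Read one bond further out, the same difference is (pyridin-2-yl)methyl to butyl, so an open saturated chain is accepted here in place of the aromatic arm, and this is the first single-place change at this position in the series. No measurement of any property of these compounds is available to account for the step.

This single pair does not separate loss of the ring from loss of its nitrogen, and phenyl in place of pyridin-2-yl on the same core would be the direct test of that. Going by these compounds, how far the gain extends with a longer chain such as pentyl, with a branched chain such as isopropyl, or with a terminal amine or carboxylic acid on the propyl chain remains open.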